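Moving the Nitrile: an Expected Value for Compound 4

The compounds below may be only part of what the source reports. "The series", "measured", "known", "first", "only" and "open" are said of these compounds alone.

Measured compounds:
- Compound 1 `CCOC(=O)NC1CC(C)(C)Oc2ccc(Cl)cc21`: in a functional assay on T98G cells (Homo sapiens) for inhibition, read by MTT assay, with a stated time of 72 h (on this read-out lower numbers stand for stronger inhibition and higher numbers for weaker inhibition), compound 1 gives "not determined" (no result reported).
- Compound 2 `CC1(C)CC(NC(=S)Nc2cccc(C#N)c2)c2cc(Cl)ccc2O1`: in this assay compound 2 gives 10000 nM.
- Compound 3 `CC1(C)CC(NC(=S)Nc2ccc(C#N)cc2)c2cc(F)ccc2O1`: in this assay compound 3 gives 19000 nM.

Among the two compounds with a number, compound 3 has the higher one, but its gap to compound 2 is small enough to lie within the scatter of this assay, so the two cannot be ranked against each other. Compound 1 carries no result.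

Compound 4 `CC1(C)CC(NC(=S)Nc2cccc(C#N)c2)c2cc(F)ccc2O1` keeps the shared core of compound 3 and differs from it in a single place: 3-cyanophenyl in place of 4-cyanophenyl on an amide-type nitrogen. Among the compounds with values here, no measured pair in this set shows this change on its own, because compound 2, the only other compound with a 3-cyanophenyl group, also carries a different halogen on the core. With so little to lean on, the step from compound 3 to compound 4 is expected to be small, most likely towards a slightly lower number but not clearly beyond the scatter, a 1.5-fold lower number from compound 3 to compound 4 (0.16 log units; within the scatter). Compound 4 is therefore estimated at 13000 nM, with a range from 5000 nM to 32000 nM.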

Compound 4, half-maximal inhibitory concentration: 39000 nM
Estimate against measurement, compound 4: 3.0-fold (0.48 log units) below; measured number above the stated range.
By their numbers in this assay, from the lowest: compounds 2 and 3 (each within the scatter of the next); then compound 4.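

In this assay the place of the nitrile on the ring now proves to matter: 3-cyanophenyl in place of 4-cyanophenyl on the amide-type nitrogen gives a 2.1-fold higher number from compound 3 to compound 4 (0.31 log units; beyond the scatter) and so weaker inhibition, the first effect of this single change that can be read. The halogen on the core counts as well, since fluoro in place of chloro on an aromatic carbon gives a 3.9-fold higher number from compound 2 to compound 4 (0.59 log units; beyond the scatter) and again weaker inhibition. Both steps are modest and each rests on a single pair, so they describe only these compounds.

No measurement at hand explains either step. As far as these compounds go, it remains open whether a carboxylic acid or a methoxy group in place of the nitrile would give a lower or a higher number, and whether chloro in place of fluoro would have the same effect on a compound with the 4-cyanophenyl group.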